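Working notes on a small cell-growth series

The source may hold more compounds than are shown below. What is called first, only, known or untested is meant among the compounds shown, and "the series" means these compounds.

Measured compounds:
- compound 1 `CN(C)c1ccc(C(=O)Nc2ccc(Oc3ncnc4ccsc34)cc2)cc1`: 53.9% in a functional assay on HCT-116 cells (Homo sapiens) for inhibition, read by MTT assay, with a stated time of 72 h, tested at 20 uM; a lower number here means less inhibition, a higher number more inhibition at the concentration tested (going by the name of the read-out)
- compound 2 `CN(c1ccc(Oc2ncnc3ccsc23)cc1)c1nccc(N2CCc3ccccc3C2)n1`: 58.3% in this assay
- compound 3 `CN(c1ccc(Oc2ncnc3sccc23)cc1)c1nccc(N2CCCC2)n1`: 42.2% in this assay

Compound 2 holds the highest of the three numbers, but compound 1 sits within the scatter of it, so no order between these two can be read. Compound 3 lies beyond the scatter below compound 2, the only gap in the set that is large enough to count.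

The step taken next is from compound 2 to compound 4 `CN(c1ccc(Oc2ncnc3ccsc23)cc1)c1nccc(N2CCc3ccccc32)n1`. The change is 2,3-dihydro-1H-indol-1-yl in place of 1,2,3,4-tetrahydroisoquinolin-2-yl on an aromatic carbon. Within the data shown here, no measured pair in this set differs in one place, so the size of such a step has not been seen; the two ring amines share the same count of donors and acceptors and differ by one heavy atom. On that basis the expected step in this assay is small, in no fixed direction, and not beyond the scatter, which is what a number 3.3 percentage points lower from compound 2 to compound 4 (within the scatter) expresses. Compound 4 is therefore estimated at 55%, with a range from 40% to 70%.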

Compound 4, a percentage reported as inhibition, at one concentration (the size of the read-out at that concentration, not a potency): 57.8%
Beside the measured number, compound 4's estimate is 2.8 percentage points below it; low and high end bracket the measured number.
By their numbers in this assay, from the lowest: compound 3; then compounds 1, 4 and 2 (each within the scatter of the next).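

Among these compounds, this is the first pair that differs in one place, and it gives that kind of step a size: a number 0.5 percentage points lower from compound 2 to compound 4 (within the scatter) in this assay. On this aromatic carbon next to the ring nitrogen, 2,3-dihydro-1H-indol-1-yl and 1,2,3,4-tetrahydroisoquinolin-2-yl cannot be told apart in this read-out, although the non-aromatic ring goes from six-membered to five-membered and the group loses one heavy atom. Nothing measured here accounts for this result.

Compound 3 differs from compound 2 and compound 4 in more than one place, so its lower number cannot be assigned to the group at this position. As far as these compounds go, whether an open-chain amine such as diethylamine, or a morpholine, on this carbon would keep the number within the scatter of compound 2 remains open.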